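The source may report more compounds than this note shows. Statements on the series, on what has been measured and on what is new or still open speak of the compounds shown alone.

Working notes on the carbamate series.

In an assay on CHO cells for displacement of a labelled ligand from muscarinic acetylcholine receptor M5 (Homo sapiens), read by scintillation counting, with a stated time of 2 h (a higher number here means a weaker inhibitor, a lower number a stronger inhibitor), compound 1 `COc1ccc(CCCOC(=O)N(c2ccccc2)C2CN3CCC2CC3)cc1OC` gives 1610 nM, the highest of the three numbers recorded so far. Compound 2 `O=C(OCCCc1ccc(F)c(F)c1)N(c1ccccc1)C1CN2CCC1CC2` gives 100 nM in this assay, and compound 3 `Cc1ccc(COC(=O)N(c2ccccc2)C2CN3CCC2CC3)cc1F` gives 30 nM; both gaps away from compound 1 lie beyond the scatter, so compound 1 is the weakest inhibitor among the measured members.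

The next member, compound 4 `O=C(OCCCc1ccccc1)N(c1ccccc1)C1CN2CCC1CC2`, differs from compound 1 in one place: phenyl in place of 3,4-dimethoxyphenyl on a saturated chain carbon, three bonds along the chain from an oxygen next to a carbonyl group. Within the data shown here, the only measured step that bears on this change is the one from compound 1 to compound 2, a 16-fold lower number from compound 1 to compound 2 (1.21 log units; beyond the scatter), where the same 3,4-dimethoxyphenyl was replaced on the same saturated chain carbon, though by 3,4-difluorophenyl rather than by plain phenyl. Compound 3 differs from compound 1 in more than one place and gives no clean comparison. Among the measured compounds shown here, with only that single step to go on, the expectation is that removing the two methoxy groups will again lower the number well beyond the scatter, though the exact size for a bare phenyl is uncertain.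

Compound 4 is therefore estimated at 150 nM in this assay, within a range from 40 nM to 600 nM. That estimate corresponds to an expected step of an 11-fold lower number from compound 1 to compound 4 (1.03 log units; beyond the scatter).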

Compound 4, inhibition constant: 260 nM
Beside the measured number, compound 4's estimate is 1.7-fold (0.24 log units) below it; the measured number falls inside the stated range.
By their numbers in this assay, from the lowest: compound 3; then compound 2; then compound 4; then compound 1.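

With phenyl as the reference on a saturated chain carbon, three bonds along the chain from an oxygen next to a carbonyl group, the two substituted rings fall on opposite sides in this assay: removing the methoxy groups gives a 6.2-fold lower number from compound 1 to compound 4 (0.79 log units; beyond the scatter), whereas removing the fluorines gives a 2.6-fold higher number from compound 2 to compound 4 (0.41 log units; beyond the scatter), so substitution on this phenyl does not act in one direction, and the gain seen earlier on going from 3,4-dimethoxyphenyl to 3,4-difluorophenyl combines a loss from one pair of substituents with a gain from the other. The change to phenethyl in place of 3-fluoro-4-methylphenyl, on a saturated chain carbon bound to an oxygen next to a carbonyl group, gives an 8.7-fold higher number from compound 3 to compound 4 (0.94 log units; beyond the scatter), but it alters the chain and the ring substituents together, so neither can be credited with that step alone. No measurement shown here accounts for any of these steps.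

The compounds shown leave open whether one methoxy or one fluorine alone would account for the steps seen with each pair. They also leave open how a 3,4-dichlorophenyl or pyridyl ring, or a longer chain carrying the 3,4-difluorophenyl, would read in this assay.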